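Methoxy in Place of Phenyl: Compound 2 to Compound 3

The source may hold more compounds than are shown below. What is called first, only, known or untested is meant among the compounds shown, and "the series" means these compounds.

Compound 1 `CCOC(=O)OC[C@H]1O[C@@H](n2cnc3c(N)ncnc32)[C@H](O)[C@@H]1O` gives in an assay on COS-7 cells for inhibition of sodium/nucleoside cotransporter 2 (Homo sapiens), read by scintillation counting, in the presence of a further agent that is not named here (a higher number here means a weaker inhibitor, a lower number a stronger inhibitor), only a limit, > 100000 nM. Among the compounds with values here, compound 2 `Nc1ncnc2c1nc(NCc1cccc(-c3ccccc3)c1)n2[C@@H]1O[C@H](CO)[C@@H](O)[C@H]1O` is the one compound with a number in this assay, where compound 2 gives 21000 nM. Compound 3 `COc1cccc(CNc2nc3c(N)ncnc3n2[C@@H]2O[C@H](CO)[C@@H](O)[C@H]2O)c1` differs from compound 2 by methoxy in place of phenyl on an aromatic carbon. Within the data shown here, no step between measured compounds is known, so the weight of this change cannot be read from the data, and only the limit of > 100000 nM in this assay, at which 1 of the 2 values shown sits, stands beside the single number. A moderate weakening in this assay is expected. Compound 3 is estimated at 50000 nM, between 15000 nM and 150000 nM. The expected step is a 2.4-fold higher number from compound 2 to compound 3 (0.38 log units; beyond the scatter).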

Compound 3, half-maximal inhibitory concentration: 13000 nM
For compound 3 the middle estimate is 3.8-fold (0.59 log units) above the measured one, outside the stated range (below it).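

In this assay, methoxy in place of phenyl on an aromatic carbon gives a 1.6-fold lower number from compound 2 to compound 3 (0.21 log units; within the scatter), so the two values cannot be told apart. At this place, meta to a large group, the six-membered aromatic ring of compound 2 is therefore not needed to keep the number, and a methoxy of 2 heavy atoms serves as well. Nothing given here offers a reason for this result. On these data alone, whether an amine, a carboxylic acid or a longer chain on this carbon would move the number beyond the scatter stays open.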